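One Substituent Swap on a Muscarinic Modulator

The source may report more compounds than this note shows. Statements on the series, on what has been measured and on what is new or still open speak of the compounds shown alone.

Compound 1: `CCN(Cc1cccc(F)c1)C(=O)C1CCN(S(=O)(=O)c2ccc3cn[nH]c3c2)CC1` — 89%
Compound 2: `CCN(Cc1cccc(Cl)c1)C(=O)C1CCN(S(=O)(=O)c2ccc3cn[nH]c3c2)CC1` — 77%

In a functional assay on CHO cells for positive allosteric modulation of muscarinic acetylcholine receptor M5 (Homo sapiens), read by calcium flux (a lower number here means a smaller maximal response, a higher number a larger maximal response), compound 1 reaches 89%, and compound 2 reaches 77%. Among the compounds with values here, the one step between them, a number 12 percentage points lower from compound 1 to compound 2 (beyond the scatter), is the only comparison available, and it places compound 2 at the lower of the two numbers, the gap to compound 1 lying beyond the scatter.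

Compound 3, `CCN(Cc1cccc(C)c1)C(=O)C1CCN(S(=O)(=O)c2ccc3cn[nH]c3c2)CC1`, carries the next change on the same position: methyl in place of chloro on an aromatic carbon. Within the data shown here, no measured step shows a methyl group taking the place of a halogen, so the fluoro-to-chloro step is the only guide, and that step was modest. Both groups leaving and entering are single heavy atoms with no donors or acceptors, so the change is of the same small kind as the one already seen. The expectation is therefore a step of no more than modest size, most likely within the scatter, with no clear direction. Compound 3 is estimated to reach 80%, within a range of 66% to 94%. That estimate corresponds to a step of a number 3 percentage points higher from compound 2 to compound 3 (within the scatter).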

Compound 3, largest response reached (reported as percent of maximum), in percent of the reference or control that the assay uses: 78%
Compound 3: middle estimate off by 2 percentage points, on the high side; measured number inside the range.
By their numbers in this assay, from the lowest: compounds 2 and 3 (each within the scatter of the next); then compound 1.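

In this assay, the chloro-to-methyl change on the aromatic carbon meta to a large group appears as a number 1 percentage points higher from compound 2 to compound 3 (within the scatter), so chloro and methyl cannot be told apart at this position, although the two groups differ in their element. Fluoro now stands apart from both, with a number 11 percentage points lower from compound 1 to compound 3 (beyond the scatter) matching in kind the earlier a number 12 percentage points lower from compound 1 to compound 2 (beyond the scatter), which leaves compound 1 as the only one of the three with a step beyond the scatter to each of the others. Nothing in hand gives a reason why the fluoro compound separates from the other two.

The compounds shown leave open whether a bare hydrogen, a methoxy group, a trifluoromethyl group, a nitrile or an amine at this position would fall with chloro and methyl, reach the level of fluoro or go elsewhere. They also leave open whether the same separation of fluoro from chloro and methyl would hold at other carbons of this ring, or with a chain other than ethyl on the amide nitrogen.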